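Cutting a large amide substituent down to methyl

The source may hold more compounds than are shown below. What is called first, only, known or untested is meant among the compounds shown, and "the series" means these compounds.

In a physicochemical assay for solubility (a lower number here means a less soluble compound, a higher number a more soluble compound), compound 2 `CCC(=O)N1C[C@@H]2[C@H](C1)[C@H]2NC(=O)c1cc(C(=O)NC)c2c(c1)[C@H](c1ccccc1)CO2` gives >= 163 ug/mL, which is a limit and not a number. Compound 1 `CNC(=O)c1cc(C(=O)N[C@H]2CC[C@H](O)CC2)cc2c1OC[C@@]2(C)c1ccccc1` also reaches only a limit, >= 161 ug/mL. Compound 3 `CNC(=O)c1cc(C(=O)NC2CC2)cc2c1OC[C@@]2(C)c1ccccc1` likewise gives a limit, >= 138 ug/mL. Compound 4 `CNC(=O)c1cc(C(=O)NC)c2c(c1)[C@H](c1ccccc1)CO2` differs from compound 2 at one place: one carbon atom in place of a group of 10 heavy atoms (8 carbon, 1 nitrogen, 1 oxygen; one three-membered non-aromatic ring of carbon only, one five-membered non-aromatic ring with 1 hetero atom), on an amide-type nitrogen. A methyl thus enters on an amide-type nitrogen. The nearest measured change is a step that the two limits leave unreadable from compound 1 to compound 3, and it offers no size to carry over. With no measured size to go on, no step beyond the usual scatter is expected in this assay. The estimated change is an at least 1.3-fold lower number from compound 2 to compound 4 (0.13 log units; that floor lies within the scatter). Compound 4 is expected near 120 ug/mL, with an estimated range of 80 ug/mL to 135 ug/mL.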

Compound 4, solubility: >= 130 ug/mL
Compound 4: no number, only a limit (the forecaster's own chance of this, stated with the estimate: 75%); middle value at least 1.0-fold (0.03 log units) from the limit.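

Compound 2 and compound 4 each give only a limit in this assay, and the step between them cannot be read. The compounds shown leave open what actual solubility number any of them would reach.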